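Moving the Naphthyl Attachment Point in a Motilin Macrocycle

The source may report more compounds than this note shows. Statements on the series, on what has been measured and on what is new or still open speak of the compounds shown alone.

Compound 1 `CCC[C@@H]1NC(=O)[C@@H](C(C)C)NC(=O)[C@@H](Cc2ccc(O)cc2)NCCOc2ccccc2CCCNC1=O`: 55 nM
Compound 2 `CCC[C@@H]1NC(=O)[C@@H](C(C)C)NC(=O)[C@@H](Cc2ccccc2)NCCOc2ccccc2CCCNC1=O`: 57 nM
Compound 3 `CCC[C@@H]1NC(=O)[C@@H](C(C)C)NC(=O)[C@@H](Cc2ccc3ccccc3c2)NCCOc2ccccc2CCCNC1=O`: 79 nM

Three macrocycles were measured in an assay on isolated protein for displacement of a labelled ligand from Motilin receptor (Homo sapiens); on this read-out higher numbers stand for weaker inhibition and lower numbers for stronger inhibition. Compound 1 gives 55 nM in this assay, compound 2 gives 57 nM and compound 3 gives 79 nM. Compound 3 has the highest of the three numbers, but its gaps to the other two lie within the scatter, so the three are not separable on this read-out.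

Compound 4 `CCC[C@@H]1NC(=O)[C@@H](C(C)C)NC(=O)[C@@H](Cc2cccc3ccccc23)NCCOc2ccccc2CCCNC1=O` has not yet been measured. It differs from compound 3 in one place: naphthalen-1-yl in place of naphthalen-2-yl on a saturated chain carbon bound to a saturated ring carbon. Within the data shown here, the steps that bear on this change are those that exchanged the aromatic group at the same position: a 1.4-fold higher number from compound 1 to compound 3 (0.16 log units; within the scatter) and a 1.4-fold higher number from compound 2 to compound 3 (0.14 log units; within the scatter). Among the measured compounds shown here, neither reached beyond the scatter, so exchanging one aromatic group for another at this position has so far produced no step of note. Compound 4 is therefore expected to show no step beyond the scatter, a 1.0-fold higher number from compound 3 to compound 4 (0.01 log units; within the scatter). Compound 4 is estimated at 80 nM, with a range from 30 nM to 220 nM.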

Compound 4, inhibition constant: 8.3 nM
Beside the measured number, compound 4's estimate is 9.6-fold (0.98 log units) above it; measured number below the stated range.
By their numbers in this assay, from the lowest: compound 4; then compounds 1, 2 and 3 (each within the scatter of the next).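

Exchanging naphthalen-2-yl for naphthalen-1-yl, which have the same atoms joined differently, gives in this assay a 9.5-fold lower number from compound 3 to compound 4 (0.98 log units; beyond the scatter) and so shows that the attachment point of the naphthalene ring system matters at this place, where the earlier aromatic exchanges stayed within the scatter. The naphthalen-1-yl group also separates from the smaller aromatic groups, with a 6.9-fold lower number from compound 2 to compound 4 (0.84 log units; beyond the scatter) and a 6.6-fold lower number from compound 1 to compound 4 (0.82 log units; beyond the scatter), leaving compound 4 as the only one of the four beyond the scatter of the rest. Nothing shown explains why the two naphthyl groups differ.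

The compounds shown leave open whether other fused aromatic groups at this place, such as indol-3-yl or quinolin-8-yl, would match naphthalen-1-yl. They also leave open whether its advantage would persist if the propyl or isopropyl groups of the shared core were replaced.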